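The source may report more compounds than this note shows. Statements on the series, on what has been measured and on what is new or still open speak of the compounds shown alone.

Measured in a functional assay on PC-3 cells (Homo sapiens) for cytotoxicity, read by MTT assay, with a stated time of 72 h; on this read-out higher numbers stand for weaker inhibition and lower numbers for stronger inhibition:
- compound 1 `N#Cc1ccc(/C=N/NC(=O)Nc2cc3c(Nc4ccc(F)c(Cl)c4)ncnc3cc2O[C@H]2CCOC2)cc1`: 28100 nM
- compound 2 `O=C(N/N=C/c1cc(Br)c(O)c(Br)c1)Nc1cc2c(Nc3ccc(F)c(Cl)c3)ncnc2cc1O[C@H]1CCOC1`: 6160 nM
- compound 3 `COc1cc2ncnc(Nc3ccc(F)c(Cl)c3)c2cc1NC(=O)N/N=C/c1ccc(C#N)cc1`: 36500 nM

Compound 3, at 36500 nM, sits level with compound 1, at 28100 nM, while compound 2 stands lower, at 6160 nM.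

Compound 4 `COc1cc2ncnc(Nc3ccc(F)c(Cl)c3)c2cc1NC(=O)N/N=C/c1ccc(OC)c(OC)c1OC` differs from compound 3 in one place: 2,3,4-trimethoxyphenyl in place of 4-cyanophenyl on a carbon with a double bond to nitrogen. For the measured compounds named here, the nearest precedent is a 4.6-fold lower number from compound 1 to compound 2 (0.66 log units; beyond the scatter), an exchange at the same place, where 3,5-dibromo-4-hydroxyphenyl takes the place of 4-cyanophenyl. The other measured step, a 1.3-fold higher number from compound 1 to compound 3 (0.11 log units; within the scatter), lies within the scatter, so the group on the oxygen gives little reason to set that precedent aside. Going by the values given here, no compound carrying 2,3,4-trimethoxyphenyl has been measured, and a single exchange is thin support.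

The expected move in this assay is a 2.4-fold lower number from compound 3 to compound 4 (0.39 log units; beyond the scatter), a lowering smaller than the precedent. Compound 4 is estimated at 15000 nM, with an expected range from 5000 nM to 40000 nM.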

Compound 4, half-maximal inhibitory concentration: 29300 nM
Estimate against measurement, compound 4: 2.0-fold (0.29 log units) below, and the stated range covers the measured number.
By their numbers in this assay, from the lowest: compound 2; then compounds 1, 4 and 3 (each within the scatter of the next).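

Exchanging 4-cyanophenyl for 2,3,4-trimethoxyphenyl on the carbon with a double bond to nitrogen gives in this assay a 1.2-fold lower number from compound 3 to compound 4 (0.10 log units; within the scatter) and so leaves the number in place. For the compounds shown here, an exchange at this place therefore does not lower the number by itself: the earlier 4.6-fold lower number from compound 1 to compound 2 (0.66 log units; beyond the scatter) now stands as the only step beyond the scatter here, and compound 4 goes against any general rule that replacing 4-cyanophenyl helps. No measured evidence is at hand that bears on the difference between these two exchanges.

Open, as far as these compounds go, is whether 3,5-dibromo-4-hydroxyphenyl gives the same lowering with methyl on the oxygen, and whether 2,3,4-trimethoxyphenyl stays level with oxolan-3-yl there. Also open, from the compounds shown here alone, is how a phenyl group carrying a carboxylic acid or an amine would read at this place.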